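A few compounds are considered here, and "the series" means these few. Any claim that something is new, unique, unknown or untested is made for them only; others in the source may bear on it.

Compound 1 `COc1cc2c(Oc3ccc(NC(=O)C4(c5nnc(-c6ccc(F)cc6)o5)CC4)cc3F)ccnc2cc1OCCCN1CCCC1` gives 2340 nM in a functional assay on PC-3 cells (Homo sapiens) for antiproliferative activity, read by MTT assay, with a stated time of 72 h; a lower number here means a stronger inhibitor, a higher number a weaker inhibitor. Compound 2 `COc1cc2c(Oc3ccc(NC(=O)C4(c5nnc(-c6ccc(F)cc6)o5)CC4)cc3F)ccnc2cc1OCCCN1CCN(C)CC1` gives 1670 nM in this assay. Compound 3 `COc1cc2c(Oc3ccc(NC(=O)c4ncc(-c5ccc(F)cc5)o4)cc3)ccnc2cc1OCCCN1CCC(C)CC1` gives 720 nM in this assay.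

Compound 2 holds the second highest of these three numbers; compound 1 lies within the scatter of it, while compound 3 sits clearly lower. Compound 4 `COc1cc2c(Oc3ccc(NC(=O)C4(c5nnc(-c6ccc(F)cc6)o5)CC4)cc3F)ccnc2cc1OCCCN1CCC(C)CC1` has not yet been measured; it differs from compound 2 by 4-methylpiperidin-1-yl in place of 4-methylpiperazin-1-yl on a saturated chain carbon, three bonds along the chain from an oxygen on an aromatic ring. Within the data shown here, one measured step touches the same place: a 1.4-fold lower number from compound 1 to compound 2 (0.15 log units; within the scatter), an exchange of the ring on that chain carbon that stayed within the scatter. Compound 3 also carries the 4-methylpiperidin-1-yl group, but it differs from compound 2 in several other places, so its value speaks only for the whole compound. The exchange is therefore expected to move the number only a little, a 1.3-fold lower number from compound 2 to compound 4 (0.11 log units; within the scatter). Compound 4 is estimated at 1300 nM, within a range from 600 nM to 3000 nM.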

Compound 4, half-maximal inhibitory concentration: 2180 nM
The estimate for compound 4 lay 1.7-fold (0.22 log units) below the measured number; the measured number falls inside the stated range.
By their numbers in this assay, from the lowest: compound 3; then compounds 2, 4 and 1 (each within the scatter of the next).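

At this chain carbon, 4-methylpiperidin-1-yl in place of 4-methylpiperazin-1-yl gives a 1.3-fold higher number from compound 2 to compound 4 (0.12 log units; within the scatter) and stays within the scatter, as does its exchange for pyrrolidin-1-yl, with a 1.1-fold lower number from compound 1 to compound 4 (0.03 log units; within the scatter) also within it. Compound 1, compound 2 and compound 4 therefore cannot be told apart in this assay, so among these three neither ring size nor the second ring nitrogen separates them. Nothing measured here explains this result. From the compounds shown here alone, whether morpholin-4-yl or an open-chain dimethylamino group would read the same remains open. So does the effect of a longer chain on this core.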